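The source may hold more compounds than are shown below. What is called first, only, known or untested is meant among the compounds shown, and "the series" means these compounds.

Measured compounds:
- Compound 1, `COc1ccc2[nH]c(C(=O)Cc3cccnc3)cc2c1OCc1ccccc1`: "not active" (no number reported)
- Compound 2, `COc1ccc2[nH]c(C(=O)Cc3cccnc3)cc2c1`: "not determined" (no result reported)
- Compound 3, `COc1ccc2[nH]c(C(=O)Cc3cccnc3)cc2c1O`: 11%

The series shares one core, and the three measured compounds differ only on the aromatic ring of that core. In an in vitro assay on P815B cells for inhibition of Indoleamine 2,3-dioxygenase 1 (Mus musculus), tested at 20 uM (on this read-out lower numbers stand for less inhibition and higher numbers for more inhibition at the one concentration tested (going by the name of the read-out)), compound 1 is recorded as "not active" (no number reported), compound 2 as "not determined" (no result reported), and compound 3 gives 11%. Compound 2 therefore stands without a single number in this assay; one further entry, compound 1, likewise carries no number. The only numerical result is that of compound 3, which is small.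

Compound 4, `O=C(Cc1cccnc1)c1cc2cc(O)ccc2[nH]1`, has not yet been measured. It differs from compound 2 by hydrogen in place of methyl on an oxygen on an aromatic ring. Going by the values given here, no step between measured compounds is available to gauge the size of such a change, and compound 2 itself has no number to serve as a starting point. The only numerical anchor is the low reading of compound 3, which suggests that this region of the series shows little inhibition. Compound 4 is therefore expected to give 10% in this assay, within a range from 0% to 30%.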

Compound 4, a percentage reported as inhibition, at one concentration (the size of the read-out at that concentration, not a potency): "not active" (no number reported)
Compound 4: no number reported, so the estimate cannot be set against anything.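

In this assay, going by these compounds alone, compound 4 is recorded as "not active" (no number reported) and compound 2 as "not determined" (no result reported) so no step between them can be read. No supporting data bear on this result. The compounds shown leave open how far going from methoxy to hydroxy shifts inhibition.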